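A few compounds are considered here, and "the series" means these few. Any claim that something is new, unique, unknown or untested is made for them only; others in the source may bear on it.

Compound 1 `CC(C)c1n[nH]c2c(NCc3ccc(-c4ccccn4)cc3)nc(SCCNC(=N)N)nc12` gives 390 nM in a functional assay on HT cells (Homo sapiens) for antiproliferative activity, read by fluorescence, with a stated time of 72 h; on this read-out higher numbers stand for weaker inhibition of growth and lower numbers for stronger inhibition of growth.
Compound 2 `CCC(O)CSc1nc(NCc2ccc(-c3ccccn3)cc2)c2[nH]nc(C(C)C)c2n1` gives 273 nM in this assay.
Compound 3 `CC(C)c1n[nH]c2c(NCc3ccc(-c4ccccn4)cc3)nc(SCC(O)CO)nc12` gives 21 nM in this assay.

Compound 2 stands second highest of these three numbers; its nearest neighbour is compound 1, at a 1.4-fold lower number from compound 1 to compound 2 (0.15 log units; within the scatter), and its furthest is compound 3, at a 13-fold lower number from compound 2 to compound 3 (1.11 log units; beyond the scatter). Compound 4 `CC(C)c1n[nH]c2c(NCc3ccc(-c4ccccn4)cc3)nc(SCC(C)(C)O)nc12` differs from compound 2 in one place: 1-hydroxy-1-methylethyl in place of 1-hydroxypropyl on a saturated chain carbon bound to a sulfur. Among the measured compounds shown here, no measured step rearranges the same atoms in this way, so none bears directly. The steps of a 19-fold lower number from compound 1 to compound 3 (1.27 log units; beyond the scatter) and a 13-fold lower number from compound 2 to compound 3 (1.11 log units; beyond the scatter) show that this chain can move the number a long way, yet both bring in a hydroxy, whereas compound 2 and compound 4 are built from the same atoms. The account therefore expects no step beyond the scatter in this assay. For compound 4 the estimate is 250 nM, between 80 nM and 750 nM, an expected step of a 1.1-fold lower number from compound 2 to compound 4 (0.04 log units; within the scatter).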

Compound 4, concentration for 50% growth inhibition: 507 nM
The estimate for compound 4 lay 2.0-fold (0.31 log units) below the measured number; low and high end bracket the measured number.
By their numbers in this assay, from the lowest: compound 3; then compounds 2, 1 and 4 (each within the scatter of the next).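

Within this assay, rearranging the same atoms on the saturated chain carbon bound to a sulfur, from 1-hydroxypropyl to 1-hydroxy-1-methylethyl, gives a 1.9-fold higher number from compound 2 to compound 4 (0.27 log units; within the scatter). Only the 1,2-dihydroxyethyl group stands apart, with a 24-fold higher number from compound 3 to compound 4 (1.38 log units; beyond the scatter), whereas the group of 5 heavy atoms and 1-hydroxy-1-methylethyl give a 1.3-fold higher number from compound 1 to compound 4 (0.11 log units; within the scatter). Nothing available here explains these steps. The compounds shown leave open whether an amine or a carboxylic acid on this chain would match the number of compound 3. They also leave open whether a longer chain carrying two hydroxy groups would do so.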